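This account rests on a few compounds, and the source may have more. Where it says the series, first, only, none or still open, it means among the compounds named here.

Compound 1 `CCCc1onc(-c2c(Cl)cccc2Cl)c1C(=O)Nc1ccc(N(CC)CC)cc1` gives 492 nM in a functional assay on CHO-K cells with growth hormone secretagogue receptor type 1 (Homo sapiens) as the target, read by FLIPR; a higher number here means a weaker inhibitor, a lower number a stronger inhibitor.
Compound 2 `CCN(CC)c1ccc(NC(=O)c2c(-c3c(Cl)cccc3Cl)noc2C(C)C)cc1` gives 861 nM in this assay.
Compound 3 `CCN(CC)c1ccc(NC(=O)c2c(-c3c(Cl)cccc3Cl)noc2CCOC)cc1` gives 115 nM in this assay.

Compound 3 holds the lowest number of the three, and both of its neighbours lie beyond the scatter: a 4.3-fold lower number from compound 1 to compound 3 (0.63 log units; beyond the scatter) and a 7.5-fold lower number from compound 2 to compound 3 (0.87 log units; beyond the scatter). These two steps are the only ones that alter the short chain carried on the core of compound 3, and each was modest in size. Compound 4 `CCN(CC)c1ccc(NC(=O)c2c(-c3c(Cl)cccc3Cl)noc2CCC2OCCCO2)cc1` alters that same chain once more: a group of 6 heavy atoms (4 carbon, 2 oxygen; one six-membered non-aromatic ring with 2 hetero atoms) in place of a group of 2 heavy atoms (1 carbon, 1 oxygen; no ring), on a saturated chain carbon, two bonds along the chain from an aromatic carbon. Within the data shown here, none of the measured steps places a ring here, so the direction of the change has no direct precedent. The chain end has so far mattered only modestly, which argues for a step of limited size in this assay rather than a large swing in either direction. The expected step is therefore a 1.7-fold higher number from compound 3 to compound 4 (0.24 log units; within the scatter), close to the scatter. Compound 4 is estimated at 200 nM in this assay, with a range from 60 nM to 700 nM.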

Compound 4, half-maximal inhibitory concentration: 19 nM
For compound 4 the middle estimate is 11-fold (1.02 log units) above the measured one; the measured number lies below the stated range.
By their numbers in this assay, from the lowest: compound 4; then compound 3; then compounds 1 and 2 (each within the scatter of the next).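

The earlier steps shown here at this chain end were modest, which left open whether a ring could be carried here at all, and compound 4 shows that it can: the six-membered non-aromatic ring with 2 hetero atoms gives a further drop beyond methoxy (a 6.1-fold lower number from compound 3 to compound 4 (0.78 log units; beyond the scatter)). Among these compounds, measured against the all-carbon chains, the change is large (a 26-fold lower number from compound 1 to compound 4 (1.41 log units; beyond the scatter); a 45-fold lower number from compound 2 to compound 4 (1.66 log units; beyond the scatter)), so the group at this position can shift the number in this assay much further than the earlier compounds suggested, and compound 4 is the strongest inhibitor of the four. No measurement at hand explains why the ring lowers the number.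

The compounds shown leave open whether the ring itself or its two oxygens account for the drop, a question that a cyclohexyl group in the same place would address. Also open, as far as these compounds go, is how an amine such as morpholine, or a longer chain ahead of the ring, would behave here.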